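The source may report more compounds than this note shows. Statements on the series, on what has been measured and on what is new or still open speak of the compounds shown alone.

Compound 1 `O=C(c1ccccn1)N1CCC(NS(=O)(=O)c2cc(S(=O)(=O)c3ccccc3)ccc2C(F)(F)F)CC1` gives 100000 nM in a physicochemical assay for solubility (on this read-out higher numbers stand for higher solubility and lower numbers for lower solubility), the highest of the three numbers recorded here. Compound 3 `CC(C)(C)OC(=O)N1CCC[C@@H]1C(=O)N1CCC(NS(=O)(=O)c2cc(S(=O)(=O)c3ccccc3)ccc2C(F)(F)F)CC1` sits nearest to it with 25000 nM, and compound 2 `N#Cc1cccc(S(=O)(=O)N2CCC(NS(=O)(=O)c3cc(S(=O)(=O)c4ccccc4)ccc3C(F)(F)F)CC2)c1` furthest with 6300 nM. Compound 4 `O=C([C@@H]1CCNC1)N1CCC(NS(=O)(=O)c2cc(S(=O)(=O)c3ccccc3)ccc2C(F)(F)F)CC1` differs from compound 1 by one change: pyrrolidin-3-yl in place of pyridin-2-yl on a carbonyl carbon. The measured steps of a 4.0-fold lower number from compound 1 to compound 3 (0.60 log units; beyond the scatter) and a 16-fold lower number from compound 1 to compound 2 (1.20 log units; beyond the scatter) both replaced the pyridin-2-yl with larger groups and both lowered the number, so neither bears directly on a change to a smaller ring with a hydrogen-bond donor. Going by the values given here, with no step of that kind to lean on, compound 4 is expected to hold its number close to that of compound 1 or move somewhat upward, a step of a 1.3-fold higher number from compound 1 to compound 4 (0.11 log units; within the scatter) that is estimated to stay near the scatter. Compound 4 is therefore estimated at 130000 nM, within 50000 nM to 320000 nM.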

Compound 4, solubility: 12500 nM
Compound 4: the middle estimate sits 10-fold (1.02 log units) above what was measured; the measured number lies below the stated range.
By their numbers in this assay, from the lowest: compounds 2, 4 and 3 (each within the scatter of the next, the first and the last beyond it); then compound 1.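

In this assay the smaller pyrrolidin-3-yl, which brings a hydrogen-bond donor, gives an 8.0-fold lower number from compound 1 to compound 4 (0.90 log units; beyond the scatter) on the same carbonyl carbon, so a lower number here does not need a group larger than pyridin-2-yl. The data also give a 2.0-fold lower number from compound 3 to compound 4 (0.30 log units; within the scatter) and a 2.0-fold higher number from compound 2 to compound 4 (0.30 log units; within the scatter) and leave compound 1 alone at the top of the four. Nothing measured here explains this result.

Open, as far as these compounds go, is whether phenyl or pyridin-3-yl on this carbonyl carbon would keep the number of compound 1, or whether only pyridin-2-yl does so.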